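Swapping the Amide Aryl Toward a Smaller Fluorinated Ring

The source may report more compounds than this note shows. Statements on the series, on what has been measured and on what is new or still open speak of the compounds shown alone.

Compound 3 `Cc1ccc(NC(=O)CSc2nccn2-c2ccc(Cl)cc2)c(Br)c1` stands highest of the three numbers measured in an ADME assay on MT4 cells (Homo sapiens) for cytotoxicity, read by MTT assay (on this read-out lower numbers stand for higher toxicity in this test and higher numbers for lower toxicity in this test), with compound 3 giving 221000 nM. Compound 1 `Cc1ccccc1NC(=O)CSc1nccn1-c1ccc(Cl)cc1` gives 160000 nM, and compound 2 `Cc1ccc(-n2ccnc2SCC(=O)Nc2ccccc2F)cc1` gives 37900 nM. Compound 4 `O=C(CSc1nccn1-c1ccc(Cl)cc1)Nc1ccccc1F` is not yet measured. For the measured compounds named here, the one measured step at the same amide-type nitrogen is a 1.4-fold higher number from compound 1 to compound 3 (0.14 log units; within the scatter). The change now is 2-fluorophenyl in place of 2-bromo-4-methylphenyl on an amide-type nitrogen. Going by the values given here, compound 2 carries the same 2-fluorophenyl group and sits lower, yet it also differs elsewhere, so no single step covers it. The step is expected to be a 2.3-fold lower number from compound 3 to compound 4 (0.37 log units; beyond the scatter), a modest drop in this assay, and compound 4 is therefore estimated at 95000 nM, within 30000 nM to 260000 nM.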

Compound 4, half-maximal cytotoxic concentration: > 345000 nM
Compound 4: no number, only a limit; the forecaster's own chance of this, stated with the estimate: 10%; middle value at least 3.6-fold (0.56 log units) away from the limit.
By their numbers in this assay, from the lowest: compound 2; then compounds 1 and 3 (each within the scatter of the next). At a limit, above all of these: compound 4.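

Compound 4 gives no number in this assay, only a limit: the limit of > 345000 nM in this assay, at which 1 of the 4 values shown sits. Placing 2-fluorophenyl on the amide-type nitrogen gives an at least 1.5-fold higher number from compound 3 to compound 4 (0.19 log units; that floor lies within the scatter), so changing this position did not lower the number, though the floor of that step lies within the scatter. Fluoro in place of methyl on an aromatic carbon gives an at least 2.1-fold higher number from compound 1 to compound 4 (0.33 log units; beyond the scatter), while chloro in place of methyl on an aromatic carbon gives an at least 9.1-fold higher number from compound 2 to compound 4 (0.95 log units; beyond the scatter), so the 2-fluorophenyl group alone does not bring the low number of compound 2. Still open, on these data alone, is how far the true value of compound 4 lies past its limit, and whether an amine or a carboxylic acid on the amide aryl ring would keep the number as high.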